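The compounds below may be only part of what the source reports. "The series", "measured", "known", "first", "only" and "open" are said of these compounds alone.

Compound 1 `CCN(CC)c1nc(Cc2c(F)cccc2F)cc(=O)[nH]1`: > 85000 nM
Compound 2 `CC1CCCN(c2nc(Cc3c(F)cccc3F)cc(=O)[nH]2)C1`: > 78000 nM

In an ADME assay on MT4 cells (Homo sapiens) for cytotoxicity, read by MTT assay, with a stated time of 4 days (on this read-out higher numbers stand for lower toxicity in this test and lower numbers for higher toxicity in this test), compound 2 gives > 78000 nM, which is a limit and not a number. Compound 1 also gives only a limit, > 85000 nM. Compound 3 `O=c1cc(Cc2c(F)cccc2F)nc(-n2cccc2)[nH]1` is still unmeasured. It differs from compound 2 as follows: 1H-pyrrol-1-yl in place of 3-methylpiperidin-1-yl on an aromatic carbon. The new group sits on the same aromatic carbon, between two ring nitrogen atoms. Going by the values given here, the only measured step, a step that the two limits leave unreadable from compound 1 to compound 2, changed the group at this place but has no size to carry over. No step beyond the usual scatter is therefore expected, though this is a weak expectation. The estimated step is a step that the limit leaves unreadable from compound 2 to compound 3. Compound 3 is expected near 80000 nM, with an estimated range of 25000 nM to 200000 nM.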

Compound 3, half-maximal cytotoxic concentration: > 87000 nM
Compound 3: a limit, no number (the forecaster's own chance of this, stated with the estimate: 70%); at least 1.0-fold (0.03 log units) between middle value and limit.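

Going by these compounds alone, compound 1, compound 2 and compound 3 all give limits, not numbers, and no step between them can be read. The compounds shown leave open whether diethylamino, 3-methylpiperidin-1-yl and 1H-pyrrol-1-yl differ at all in toxicity to these cells.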